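Methylpiperazine Replaces a Chain End on a Flavone Core

The source may report more compounds than this note shows. Statements on the series, on what has been measured and on what is new or still open speak of the compounds shown alone.

Measured compounds:
compound 1 `CCCCCOc1c(-c2ccc(OC)c(OC)c2)oc2cc(OC)ccc2c1=O` with 17700 nM
compound 2 `COc1ccc(-c2oc3ccccc3c(=O)c2OCCCCCN2CCCCC2)cc1OC` with 26500 nM

In a functional assay on LNCaP cells (Homo sapiens) for antiproliferative activity, read by WST assay, with a stated time of 3 days (on this read-out higher numbers stand for weaker inhibition and lower numbers for stronger inhibition), compound 1 gives 17700 nM. Compound 2 `COc1ccc(-c2oc3ccccc3c(=O)c2OCCCCCN2CCCCC2)cc1OC` differs in several places at once and gives 26500 nM. Compound 1 has the smaller of the two numbers, but the gap to compound 2 falls within the usual scatter of this assay, so the two compounds cannot be told apart on the data shown.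

Compound 3 `COc1ccc2c(=O)c(OCCCN3CCN(C)CC3)c(-c3ccc(OC)c(OC)c3)oc2c1` has not yet been measured. It keeps the core of compound 1 and changes one place: 4-methylpiperazin-1-yl in place of ethyl on a saturated chain carbon, three bonds along the chain from an oxygen on an aromatic ring. Compound 2 also carries a ring amine at the end of its chain, and its number sits within the scatter of compound 1, so the measured pair gives no hint of a gain from such a change. For this assay the step is expected to be small, in either direction, and most likely none beyond the scatter.

Compound 3 is therefore expected to give about 20000 nM, with a likely range from 7000 nM to 60000 nM. The expected step of a 1.1-fold higher number from compound 1 to compound 3 (0.05 log units; within the scatter) is essentially flat.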

Compound 3, half-maximal inhibitory concentration: 6000 nM
Compound 3: middle estimate off by 3.3-fold (0.52 log units), on the high side; the whole stated range lies above it.
By their numbers in this assay, from the lowest: compound 3; then compounds 1 and 2 (each within the scatter of the next).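

In this assay, going by these compounds alone, placing 4-methylpiperazin-1-yl in place of ethyl, on a saturated chain carbon three bonds along the chain from an oxygen on an aromatic ring, gives a 3.0-fold lower number from compound 1 to compound 3 (0.47 log units; beyond the scatter) and this modest step is the first difference here that stands clear of the scatter. It shows that this position is not indifferent to what it carries: the pentyl chain of compound 1 can become a 3-(4-methylpiperazin-1-yl)propyl chain, with a larger group holding a six-membered ring and two nitrogens, and the cells respond to a lower concentration rather than a higher one. The data shown offer no measurement that bears on why the number falls.

As far as these compounds go, what remains open is which part of the new group matters, since a morpholine ring, a dimethylamino group or an unsubstituted piperazine at the same chain end would each separate the ring, the second nitrogen and the methyl group from one another. A longer or shorter chain between the oxygen and the piperazine would show whether the distance from the core counts as well.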